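Acetyl series: replacing the 2,4-difluorophenyl group

The source may report more compounds than this note shows. Statements on the series, on what has been measured and on what is new or still open speak of the compounds shown alone.

- Compound 1 `COc1cc(-n2c(-c3ccc(Br)cc3)cn(C(C)=O)c2=O)cc(OC)c1OC` gives 3800 nM in a functional assay on ECa-109 cells (Homo sapiens) for cytotoxicity, read by MTT assay, with a stated time of 48 h; a higher number here means a weaker inhibitor, a lower number a stronger inhibitor
- Compound 2 `COc1cc(-n2c(-c3ccc(F)cc3F)cn(C(C)=O)c2=O)cc(OC)c1OC` gives > 50000 nM in this assay (a limit, not a number)

Compound 2 stands only at a limit of the assay, so it has no exact position. Compound 3 `COc1ccc(-c2cn(C(C)=O)c(=O)n2-c2cc(OC)c(OC)c(OC)c2)cc1OC` differs from it at one place (3,4-dimethoxyphenyl in place of 2,4-difluorophenyl on an aromatic carbon). Within the data shown here, the one measured step at this place, an at least 13-fold higher number from compound 1 to compound 2 (1.11 log units; beyond the scatter), was large and beyond the scatter. A move to a lower number is therefore expected in this assay, of uncertain size. The expected change is an at least 4.1-fold lower number from compound 2 to compound 3 (0.61 log units; beyond the scatter). For compound 3 the estimated value is 12000 nM, with an expected range of 2500 nM to 50000 nM.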

Compound 3, half-maximal inhibitory concentration: > 50000 nM
Compound 3: no number, only a limit; the forecaster's own chance of this, stated with the estimate: 30%; middle value at least 4.1-fold (0.61 log units) from the limit.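

In this assay compound 3 gives > 50000 nM, a limit of the assay and not a number. A second replacement of 4-bromophenyl on this aromatic carbon, now 3,4-dimethoxyphenyl, also ends at the limit, with an at least 13-fold higher number from compound 1 to compound 3 (1.11 log units; beyond the scatter), so the measurable value at this position still rests on 4-bromophenyl alone. The step between compound 2 and compound 3 cannot be read, and their two groups cannot be ranked: the limit of > 50000 nM in this assay, at which 2 of the 3 values shown sit.

Still open, from the compounds shown here alone, is whether the bromine itself matters. Plain phenyl or 4-chlorophenyl on this carbon would address that.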